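This account rests on a few compounds, and the source may have more. Where it says the series, first, only, none or still open, it means among the compounds named here.

Measured compounds:
- compound 1 `COc1ccnc(NC[C@@H]2C[C@@H](OCC(=O)NC[C@H](NS(=O)(=O)c3c(C)cc(C)cc3C)C(=O)O)CN2C(=O)OCc2ccccc2)c1`: 1.1 nM
- compound 2 `CC(C)(C)CC(=O)N1C[C@H](OCC(=O)NC[C@H](NC(=O)C2(C)CCCCC2)C(=O)O)C[C@H]1CNc1ccccn1`: 1.4 nM
- compound 3 `COc1ccnc(NC[C@@H]2C[C@@H](OCC(=O)NC[C@H](NC(=O)c3c(C)cc(C)cc3C)C(=O)O)CN2C(=O)OCc2ccccc2)c1`: 0.54 nM

All three were tested in an assay on a protein complex for inhibition of integrin alpha-5/beta-1 (Homo sapiens), read by ELISA; a higher number here means a weaker inhibitor, a lower number a stronger inhibitor. Compound 3 gives the lowest of the three numbers, with 0.54 nM. Its nearest neighbour is compound 1, whose value of 1.1 nM stands one step away: a 2.0-fold lower number from compound 1 to compound 3 (0.31 log units; beyond the scatter). Compound 2, with 1.4 nM, gives the highest number of the three, but it differs from compound 3 in more than one place, so its two values show only that both sit within a narrow band of potent inhibitors.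

Compound 4 `COc1ccnc(NC[C@@H]2C[C@@H](OCC(=O)NC[C@H](NC(=O)c3c(C)cc(C)cc3C)C(=O)O)CN2C(=O)CC(C)(C)C)c1` is not yet measured. It keeps the whole of compound 3 except at the ring nitrogen: neopentyl in place of benzyloxy on a carbonyl carbon. Going by the values given here, no measured pair isolates this exchange. Compound 2 carries the same neopentylcarbonyl group on its ring nitrogen and still gives 1.4 nM, which shows that this group is compatible with low numbers in this assay, though the other differences in compound 2 leave the size of any step open. Among the compounds with values here, with no direct step to lean on, the expectation for compound 4 is a step of about a 1.5-fold higher number from compound 3 to compound 4 (0.17 log units; within the scatter), most likely none beyond the scatter, and compound 4 is estimated at 0.8 nM, in the range 0.3 nM to 2.5 nM.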

Compound 4, half-maximal inhibitory concentration: 0.55 nM
For compound 4 the middle estimate is 1.5-fold (0.16 log units) above the measured one; measured number inside the range.
By their numbers in this assay, from the lowest: compounds 3, 4, 1 and 2 (each within the scatter of the next, the first and the last beyond it).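

In this assay, going by these compounds alone, the exchange gives a 1.0-fold higher number from compound 3 to compound 4 (0.01 log units; within the scatter), the first direct reading of this position, and on this core benzyloxycarbonyl and neopentylcarbonyl cannot be told apart. The benzyloxy group takes with it a six-membered aromatic ring of carbon only and a hydrogen-bond acceptor, yet compound 3 and compound 4 lie within the scatter of each other, so in this pair neither feature is needed for a value at this level. Nothing available explains why the two groups read alike.

From the compounds shown here alone, both groups sit on a carbonyl carbon and carry no charge, so it remains open how this assay would respond if that carbonyl carbon instead carried a chain ending in an amine or a carboxylic acid, or a much shorter group such as methyl. Going by these compounds, it is also open whether neopentyl and benzyloxy would still read alike with the (2,4,6-trimethylphenyl)sulfonyl group of compound 1 on the other side of the molecule.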